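The source may hold more compounds than are shown below. What is called first, only, known or untested is meant among the compounds shown, and "the series" means these compounds.

Measured so far, in a functional assay on PC-3 cells (Homo sapiens) for antiproliferative activity, read by MTT assay, with a stated time of 48 h; a higher number here means a weaker inhibitor, a lower number a stronger inhibitor:
- compound 1, `O=C1c2ccccc2C(=O)N1c1nc(-c2ccc(Cl)cc2)cs1`: 44900 nM
- compound 2, `COc1ccc(-c2csc(N3C(=O)c4ccccc4C3=O)n2)cc1`: 42900 nM
- compound 3, `O=C1c2ccc(F)cc2C(=O)N1c1nc(-c2ccc(Cl)cc2)cs1`: 38000 nM

The three numbers sit close together. Compound 3 differs from compound 1 by fluoro in place of hydrogen on an aromatic carbon, and a 1.2-fold lower number from compound 1 to compound 3 (0.07 log units; within the scatter) stays within the scatter; its gap to compound 2 is within the scatter as well.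

Compound 4, `COc1ccc(-c2csc(N3C(=O)c4ccc(F)cc4C3=O)n2)cc1`, carries the change methoxy in place of chloro on an aromatic carbon on the frame of compound 3. The same change was measured on the frame of compound 1, where a 1.0-fold lower number from compound 1 to compound 2 (0.02 log units; within the scatter) was within the scatter. Going by the values given here, no other measured step bears on it. Accordingly, for compound 4 in this assay a step of a 1.0-fold lower number from compound 3 to compound 4 (0.01 log units; within the scatter) is expected, none beyond the scatter. Compound 4 is estimated at 37000 nM, with a range of 20000 nM to 70000 nM.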

Compound 4, half-maximal inhibitory concentration: 41300 nM
Estimate against measurement, compound 4: 1.1-fold (0.05 log units) below; low and high end bracket the measured number.
By their numbers in this assay, from the lowest: compounds 3, 4, 2 and 1 (each within the scatter of the next).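

In this assay, the change from 4-chlorophenyl to 4-methoxyphenyl now has a second reading on the core of compound 3, a 1.1-fold higher number from compound 3 to compound 4 (0.04 log units; within the scatter) and it agrees with the first: the same change on two cores in this assay, a 1.0-fold lower number (0.02 log units; within the scatter) from compound 1 to compound 2 and a 1.1-fold higher number (0.04 log units; within the scatter) from compound 3 to compound 4, 1.1-fold (0.06 log units) apart, within the scatter of two such steps

Fluoro in place of hydrogen likewise has a second reading on the methoxy frame, a 1.0-fold lower number from compound 2 to compound 4 (0.02 log units; within the scatter) and the two readings agree: the same change on two cores in this assay, a 1.2-fold lower number (0.07 log units; within the scatter) from compound 1 to compound 3 and a 1.0-fold lower number (0.02 log units; within the scatter) from compound 2 to compound 4, 1.1-fold (0.06 log units) apart, within the scatter of two such steps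

Across these compounds, neither change moves the number beyond the scatter, alone or combined.

Open: whether an amine, a carboxylic acid or a longer alkoxy chain in place of methoxy would move the number beyond the scatter.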